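Extending a hydroxymethyl group on the shared core

The compounds below may be only part of what the source reports. "The series", "measured", "known", "first", "only" and "open" are said of these compounds alone.

Compound 1, `Cc1cc(Cl)cc(-c2ccnc3cc(CN4C(=O)C5C(C4=O)C5(C)C)sc23)c1C[C@@H]1CNCCO1`, gives 0.44 nM in an assay on isolated protein for inhibition of ubiquitin carboxyl-terminal hydrolase 7 (Homo sapiens), read by fluorescence, with stated times of 30 min and 1 h; on this read-out lower numbers stand for stronger inhibition and higher numbers for weaker inhibition.
Compound 2, `O=C([C@H]1Cc2cc(Cl)cc(-c3ccnc4cc(CO)sc34)c2O1)N1CCNCC1`, gives 43 nM in this assay.
Compound 3, `Cc1cc(Cl)cc(-c2ccnc3cc(CN4C(=O)C5C(C4=O)C5(C)C)sc23)c1NC1CCCNC1`, gives 0.78 nM in this assay.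

Compound 2 gives the highest number of the three, and compounds 1 and 3 both lie well below it, beyond the scatter. Compound 4, `O=C([C@H]1Cc2cc(Cl)cc(-c3ccnc4cc(C(O)(CO)CCl)sc34)c2O1)N1CCNCC1`, differs from compound 2 in one place: 1-(chloromethyl)-1,2-dihydroxyethyl in place of hydroxymethyl on an aromatic carbon. Within the data shown here, the only measured step, a 1.8-fold higher number from compound 1 to compound 3 (0.25 log units; within the scatter), alters a group on a different aromatic carbon and so bears only weakly on this change. Among the measured compounds shown here, no measured pair changes the group at this position, so nothing points in either direction. Compound 4 is therefore expected to give about 40 nM in this assay, with a range from 15 nM to 120 nM. This estimate amounts to an expected step of a 1.1-fold lower number from compound 2 to compound 4 (0.03 log units; within the scatter), within the scatter.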

Compound 4, half-maximal inhibitory concentration: 9 nM
Beside the measured number, compound 4's estimate is 4.4-fold (0.65 log units) above it; measured number outside the range, below it.
By their numbers in this assay, from the lowest: compounds 1 and 3 (each within the scatter of the next); then compound 4; then compound 2.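

This position, on an aromatic carbon next to the ring sulfur, accepts a group larger than hydroxymethyl: in this assay, 1-(chloromethyl)-1,2-dihydroxyethyl gives a 4.8-fold lower number from compound 2 to compound 4 (0.68 log units; beyond the scatter). The step is modest, but it shows that changing the group at this position can move the number, and here the larger group gives stronger inhibition. Nothing in the data explains this gain.

Going by these compounds, it remains open which part of the new group matters, the chloromethyl or the hydroxyl groups. On these data alone, how an amine or a carboxylic acid would compare at this position also remains open.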